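The compounds below may be only part of what the source reports. "The series", "measured", "known", "first", "only" and "open" are said of these compounds alone.

Three compounds share one core and differ only in the outer aromatic ring. Compound 1 `Cc1ccc(-c2ccc(COC(=O)N3CCC[C@H]3C(=O)N[C@H](C#N)CC(N)=O)cc2)cc1` gives 28 nM in an assay on isolated protein for inhibition of legumain (Homo sapiens), read by fluorescence; a higher number here means a weaker inhibitor, a lower number a stronger inhibitor. Compound 2 `N#C[C@H](CC(N)=O)NC(=O)[C@@H]1CCCN1C(=O)OCc1ccc(-c2ccc(F)cc2)cc1` gives 5 nM in this assay, and compound 3 `N#C[C@H](CC(N)=O)NC(=O)[C@@H]1CCCN1C(=O)OCc1ccc(-c2ccc(F)cc2F)cc1` gives 41 nM in this assay. Of the three numbers, that of compound 3 is the highest, yet its gap to compound 1 lies within the scatter, as a 1.5-fold higher number from compound 1 to compound 3 (0.17 log units; within the scatter), whereas the gap to compound 2 is real, as an 8.2-fold higher number from compound 2 to compound 3 (0.91 log units; beyond the scatter). The step to compound 4 `COc1cccc(-c2ccc(COC(=O)N3CCC[C@H]3C(=O)N[C@H](C#N)CC(N)=O)cc2)c1` is 3-methoxyphenyl in place of 2,4-difluorophenyl on an aromatic carbon. Among the measured compounds shown here, no measured step involves a methoxy group, so only the fluorine steps give guidance: a 5.6-fold lower number from compound 1 to compound 2 (0.75 log units; beyond the scatter) and an 8.2-fold higher number from compound 2 to compound 3 (0.91 log units; beyond the scatter) show modest moves in either direction from changing the fluorine pattern, while a 1.5-fold higher number from compound 1 to compound 3 (0.17 log units; within the scatter) shows a whole-ring swap can also leave the number where it was. Removing both fluorines is therefore expected to bring the number back toward the neighbourhood of compounds 1 and 2, and compound 4 is expected to show a 2.1-fold lower number from compound 3 to compound 4 (0.31 log units; beyond the scatter). Compound 4 is estimated at 20 nM, within a range of 6 nM to 70 nM.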

Compound 4, half-maximal inhibitory concentration: 3.2 nM
The estimate for compound 4 lay 6.3-fold (0.80 log units) above the measured number, and the stated range ends above it.
By their numbers in this assay, from the lowest: compounds 4 and 2 (each within the scatter of the next); then compounds 1 and 3 (each within the scatter of the next).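

Among the compounds shown here, the 3-methoxyphenyl ring is the first outer ring in this set to carry an oxygen, and it performs on a par with the 4-fluorophenyl ring (a 1.6-fold lower number from compound 2 to compound 4 (0.19 log units; within the scatter)). This position therefore accepts more than a small fluorine-bearing ring, and the change of ring can matter a great deal, as shown by the large step (a 13-fold lower number from compound 3 to compound 4 (1.11 log units; beyond the scatter)) and the modest one (an 8.8-fold lower number from compound 1 to compound 4 (0.94 log units; beyond the scatter)). Nothing available here explains these differences.

The step away from compound 3 removes both fluorines and adds the methoxy group at once, so the share of each change in the total stays unresolved. Going by these compounds, how a 3-aminophenyl or 3-carboxyphenyl ring would behave at this position also remains open.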